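Methylphenyl in Place of Fluorophenyl on a Sulfur Linker

A few compounds are considered here, and "the series" means these few. Any claim that something is new, unique, unknown or untested is made for them only; others in the source may bear on it.

In a functional assay on SMMC-7721 cells (Homo sapiens) for inhibition, read by CCK-8 assay, with a stated time of 72 h, tested at 2 uM (on this read-out lower numbers stand for less inhibition of growth and higher numbers for more inhibition of growth at the one concentration tested), three compounds have been measured:
compound 1, `Nc1ccccc1NC(=O)/C=C/c1ccc(CSc2cccc(F)c2)cc1`, gave 8.56%;
compound 2, `Nc1ccccc1NC(=O)c1ccc(CSc2cccc(F)c2)cc1`, gave 18.6%;
compound 3, `Cc1ccc(SCc2ccc(/C=C/C(=O)Nc3ccccc3N)cc2)cc1`, gave 22%.

Compound 2 and compound 1 differ in more than one place, and the difference between their cores is not broken down here. Compound 2 stands nearest to compound 3, within the scatter, and its gap to compound 1 also lies within the scatter. Compound 1 and compound 3 differ by 4-methylphenyl in place of 3-fluorophenyl on a sulfur, and this gave a number 13.4 percentage points higher from compound 1 to compound 3 (beyond the scatter).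

Compound 4, `Cc1ccc(SCc2ccc(C(=O)Nc3ccccc3N)cc2)cc1`, has not yet been measured. It differs from compound 2 by 4-methylphenyl in place of 3-fluorophenyl on a sulfur, the same change as between compound 1 and compound 3, made at the same place. Because the change gave a number 13.4 percentage points higher from compound 1 to compound 3 (beyond the scatter), a step of similar direction is expected from compound 2 to compound 4, namely a number 11.4 percentage points higher from compound 2 to compound 4 (beyond the scatter), with allowance for the scatter of single measurements. Compound 4 is therefore estimated to reach 30%, between 16% and 44%.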

Compound 4, percent growth inhibition at one concentration: 25.1%
Compound 4: the middle estimate sits 4.9 percentage points above what was measured; the range from low to high includes it.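

In this assay, 4-methylphenyl in place of 3-fluorophenyl on a sulfur gave a number 6.5 percentage points higher from compound 2 to compound 4 (within the scatter). Set beside the earlier step, the change does not read differently on the two cores: the same change on two cores in this assay, a number 13.4 percentage points higher (beyond the scatter) from compound 1 to compound 3 and a number 6.5 percentage points higher (within the scatter) from compound 2 to compound 4, 6.9 percentage points apart, within the scatter of two such steps. Among the compounds shown here, this agreement shows that the two steps are compatible with one another, but it does not show a dependable gain on both cores: only the step on the core of compound 1 stands beyond the scatter, the step on the core of compound 2 does not, and two cores tested at one concentration in one cell line cannot establish how the change behaves on any other core.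

The compounds shown leave open whether the step would hold with other groups in the same place, such as a phenyl ring carrying an amine or a carboxylic acid, or one carrying a longer chain in place of the methyl group. They also leave open whether the same step would appear in a full concentration series rather than at the single concentration used here.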